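Hydroxyphenyl placement in the shared core

The source may hold more compounds than are shown below. What is called first, only, known or untested is meant among the compounds shown, and "the series" means these compounds.

Measured so far in a functional assay on HeLa cells (Homo sapiens) for inhibition; a higher number here means a weaker inhibitor, a lower number a stronger inhibitor:
compound 1 `Oc1ccccc1-c1cc(-c2ccc(F)cc2)cc(-c2ccccc2O)n1` gives > 50000 nM, a limit of the assay and not a number.
compound 2 `Oc1cccc(-c2cc(-c3ccc(F)cc3)cc(-c3ccccc3O)n2)c1` gives > 50000 nM, again a limit of the assay.
compound 3 `Oc1ccccc1-c1cc(-c2ccccc2OC(F)(F)F)cc(-c2ccccc2O)n1` gives 9750 nM.

Among the measured compounds shown here, compound 3 therefore holds the only number in the set; the limit of > 50000 nM in this assay, at which 2 of the 3 values shown sit, is the point at which the other two values sit. The step that the two limits leave unreadable from compound 1 to compound 2 is accordingly unreadable in this assay. The difference between the cores of compound 1 and compound 3 is not broken down here.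

Compound 4 `Oc1cccc(-c2cc(-c3ccccc3OC(F)(F)F)cc(-c3ccccc3O)n2)c1`, not yet measured, relates to compound 3 as compound 2 relates to compound 1: 3-hydroxyphenyl in place of 2-hydroxyphenyl on an aromatic carbon set against (3-hydroxyphenyl in place of 2-hydroxyphenyl on an aromatic carbon). The two places are not identical: in compound 1 the place is meta to a 4-fluorophenyl group, in compound 3 meta to a large group, so this is the same kind of change rather than the same change.

With the earlier step unreadable, the expectation for compound 4 rests mainly on compound 3 at 9750 nM. For the measured compounds named here, compound 2 contributes only that its value is a limit. The step from compound 3 to compound 4 is expected to be a 2.3-fold higher number from compound 3 to compound 4 (0.35 log units; beyond the scatter) in this assay, with a considerable chance that only a limit is reported. Compound 4 is estimated at 22000 nM, between 7000 nM and 50000 nM.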

Compound 4, half-maximal inhibitory concentration: 15200 nM
Beside the measured number, compound 4's estimate is 1.4-fold (0.16 log units) above it, within the range that was stated.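

In this assay, 3-hydroxyphenyl in place of 2-hydroxyphenyl on the core of compound 3 gives a 1.6-fold higher number from compound 3 to compound 4 (0.19 log units; within the scatter), so the two compounds cannot be told apart on this core. On the core of compound 1 the same kind of change cannot be read, because compound 1 and compound 2 both stand at a limit of the assay and not at a number: the limit of > 50000 nM in this assay, at which 2 of the 4 values shown sit. Among the compounds shown here, the series therefore holds only one readable instance of this change, which shows no readable difference on a single core and does not show that the same result carries over to the core of compound 1.

The compounds shown leave open whether an amine or a carboxylic acid in place of the hydroxyl of the 3-hydroxyphenyl group would give a value that can be told apart from those of compound 3 and compound 4. They also leave open how a longer chain in place of the 4-fluorophenyl group of compound 1 would read in this assay.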